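A few compounds are considered here, and "the series" means these few. Any claim that something is new, unique, unknown or untested is made for them only; others in the source may bear on it.

Working notes on the series built on the shared core of compound 1 `N#Cc1c(-c2ccc(F)cc2)nc2c(c(-c3ccccc3)nn2-c2ccccc2)c1-c1ccc(O)cc1`. In a functional assay on CCRF-CEM cells (Homo sapiens) for antiproliferative activity, read by resazurin assay, with a stated time of 72 h (a lower number here means a stronger inhibitor, a higher number a weaker inhibitor), compound 1 gives > 25000 nM, which is a limit of the assay and not a number; it corresponds to the limit of > 25000 nM in this assay, at which 1 of the 2 values shown sits. Going by the values given here, compound 2 `Cc1ccc(-c2nc3c(c(-c4ccccc4)nn3-c3ccccc3)c(-c3ccc(O)cc3)c2C#N)cc1` carries a methyl where compound 1 carries a fluoro, and in this assay compound 2 gives 13400 nM, the only number measured so far. The remaining value, that of compound 1, is a limit of the assay. Among the compounds with values here, the single measured step, an at least 1.8-fold lower number from compound 1 to compound 2 (0.27 log units; that floor lies within the scatter), is therefore known only as a floor and sits inside the usual scatter.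

Compound 3 `N#Cc1c(-c2ccc(Cl)cc2)nc2c(c(-c3ccccc3)nn2-c2ccccc2)c1-c1ccc(O)cc1` is the next member and differs from compound 2 as follows: chloro in place of methyl on an aromatic carbon. Within the data shown here, the only measured step that bears on this change is the fluoro-to-methyl step from compound 1 to compound 2, and it fixes no clear size or direction, since the value of compound 1 is a limit. No step beyond the scatter is therefore expected in this assay, with some weight given to a weaker number because compound 1, carrying the other halogen in this position, gave > 25000 nM.

For compound 3 the expected step is a 1.3-fold higher number from compound 2 to compound 3 (0.13 log units; within the scatter). Compound 3 is estimated at 18000 nM, with a range of 8000 nM to 40000 nM.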

Compound 3, half-maximal inhibitory concentration: 43100 nM
Compound 3: the middle estimate sits 2.4-fold (0.38 log units) below what was measured; the measured number lies above the stated range.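

In this assay, going by these compounds alone, the change from 4-methylphenyl to 4-chlorophenyl gives a 3.2-fold higher number from compound 2 to compound 3 (0.51 log units; beyond the scatter), the first readable step that lies beyond the scatter. The earlier fluoro-to-methyl step was known only as a floor inside the scatter, whereas this one shows that the number responds to the group held at this position, para to a large group, with methyl giving the lower number of the pair. Compound 1 is a limit of the assay, so the step from it to compound 3 cannot be read, and the two halogens cannot be ranked against each other: the limit of > 25000 nM in this assay, at which 1 of the 3 values shown sits.

The compounds shown cover only fluoro, methyl and chloro at this position, so it stays open how an amine, a methoxy group or a carboxylic acid would read here, and whether any group brings the number well down from that of these three. Also open, from the compounds shown here alone, is whether the gap between methyl and chloro holds when the other groups on the shared core are changed.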